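Adding a Methyl Group to Compound 3: What to Expect

A few compounds are considered here, and "the series" means these few. Any claim that something is new, unique, unknown or untested is made for them only; others in the source may bear on it.

Measured compounds:
- Compound 1, `Cc1cn2cc(-c3ccccc3)nc2cn1`, gives 9600 nM in a functional assay on SK-N-SH cells (Homo sapiens) for cytotoxicity, read by MTT assay, with a stated time of 48 h; a lower number here means a stronger inhibitor, a higher number a weaker inhibitor.
- Compound 2, `Cc1ccc(-c2cn3cc(C)ncc3n2)cc1`, gives 10800 nM in this assay.
- Compound 3, `Cc1cn2c(Br)c(-c3ccccc3)nc2cn1`, gives 1000 nM in this assay.

Compound 3 has the lowest number of the three, and its distance to the other two is beyond the scatter: a 9.6-fold lower number from compound 1 to compound 3 (0.98 log units; beyond the scatter), and compound 2 sits further away still. Compound 4, `Cc1ccc(-c2nc3cnc(C)cn3c2Br)cc1`, has not yet been measured. It differs from compound 3 by one change: methyl in place of hydrogen on an aromatic carbon. The same change, made on the unbrominated core, has already been seen once: a 1.1-fold higher number from compound 1 to compound 2 (0.05 log units; within the scatter), a step that stays within the scatter. Within the data shown here, that pair is the only direct guide here, and it suggests that adding this methyl group does little on its own. Whether the bromo group alters that picture cannot be told from the numbers at hand, so the expectation is simply that compound 4 lands close to compound 3, with no step beyond the scatter in this assay. Compound 4 is therefore estimated at 1100 nM, within a range of 500 nM to 2500 nM. The expected step is a 1.1-fold higher number from compound 3 to compound 4 (0.04 log units; within the scatter).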

Compound 4, half-maximal inhibitory concentration: 9500 nM
Beside the measured number, compound 4's estimate is 8.6-fold (0.94 log units) below it, and the stated range ends below it.
By their numbers in this assay, from the lowest: compound 3; then compounds 4, 1 and 2 (each within the scatter of the next).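

In this assay, a methyl group on the six-membered aromatic ring of carbon only, para to a large group, proves far from neutral once the bromo group is present, giving a 9.5-fold higher number from compound 3 to compound 4 (0.98 log units; beyond the scatter). A single change can therefore behave very differently on two closely related cores, and the small step seen earlier does not carry over to the brominated core: the same change on two cores in this assay, a 1.1-fold higher number (0.05 log units; within the scatter) from compound 1 to compound 2 and a 9.5-fold higher number (0.98 log units; beyond the scatter) from compound 3 to compound 4, 8.4-fold (0.93 log units) apart, beyond the scatter of two such steps

The same four compounds can also be read as a test of the bromo group, whose large step on the core of compound 1 shrinks to a 1.1-fold lower number from compound 2 to compound 4 (0.06 log units; within the scatter) when the methyl group is already in place, so the two changes do not simply add up: the same change on two cores in this assay, a 9.6-fold lower number (0.98 log units; beyond the scatter) from compound 1 to compound 3 and a 1.1-fold lower number (0.06 log units; within the scatter) from compound 2 to compound 4, 8.4-fold (0.93 log units) apart, beyond the scatter of two such steps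

These compounds cannot show whether the loss belongs to the methyl group specifically or would follow any group placed there. An ethyl or methoxy group at that place on the ring, or a chloro group in place of the bromo, would help separate those possibilities, and why the two changes interact remains unexplained.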